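A few compounds are considered here, and "the series" means these few. Any claim that something is new, unique, unknown or untested is made for them only; others in the source may bear on it.

Compound 3 `CCCCCCCCNc1cnc(C(=O)NCc2ccccc2)cn1` was tested in an ADME assay on HeLa cells (Homo sapiens) for cytotoxicity, read by microscopy, with a stated time of 6 days (on this read-out higher numbers stand for lower toxicity in this test and lower numbers for higher toxicity in this test), where compound 3 gives 100000 nM. Compound 2 `CCCCNc1cnc(C(=O)NCc2ccccc2)cn1` differs from it by hydrogen in place of butyl on a saturated chain carbon, four bonds along the chain from a nitrogen on an aromatic ring. In this assay compound 2 reaches only a limit of the assay, > 100000 nM. The step of a number no lower from compound 3 to compound 2 (the limit leaves the size open) cannot be sized because of the limit of > 100000 nM in this assay, at which 2 of the 3 values shown sit. Compound 1 `CCCCCCCCNc1nccnc1C(=O)NCc1ccccc1` has the same atoms as compound 3, joined differently; the difference between the two cores is not broken down here. In this assay compound 1 likewise gives only a limit, > 100000 nM. Compound 4 `CCCCNc1nccnc1C(=O)NCc1ccccc1` differs from compound 1 by hydrogen in place of butyl on a saturated chain carbon, four bonds along the chain from a nitrogen on an aromatic ring, the same change as between compound 3 and compound 2. The expected step of a number no higher from compound 1 to compound 4 (the limit leaves the size open) rests on the measured step of a number no lower from compound 3 to compound 2 (the limit leaves the size open). Compound 4 is therefore estimated at 100000 nM, between 50000 nM and 200000 nM, most likely again as a limit.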

Compound 4, minimum cytotoxic concentration: > 100000 nM
Compound 4: a limit, no number; the forecaster's own chance of this, stated with the estimate: 75%; the middle value lies on the limit itself.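

The step from compound 1 to compound 4 cannot be read because both compounds give only a limit in this assay: the limit of > 100000 nM in this assay, at which 3 of the 4 values shown sit. The compounds shown leave open whether this chain change alters the minimum cytotoxic concentration on either core.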